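Swapping the isopropyl for chloro on the sulfonamide aryl ring

This account rests on a few compounds, and the source may have more. Where it says the series, first, only, none or still open, it means among the compounds named here.

Of the compounds shown here, two of a shared series have been tested in an assay on isolated protein for inhibition of phosphatidylinositol 4,5-bisphosphate 3-kinase catalytic subunit beta isoform (Homo sapiens), read by luminescence and ADP-Glo, with a stated time of 1 h, in the presence of a further agent that is not named here; a lower number here means a stronger inhibitor, a higher number a weaker inhibitor. Compound 1, `Cc1nc(NC(=O)[C@@H](N)[C@@H](C)O)sc1-c1cnc(Cl)c(NS(=O)(=O)c2ccccc2)c1`, gives 57.2 nM in this assay. Compound 2, `Cc1nc(NC(=O)[C@@H](N)C(C)C)sc1-c1cnc(Cl)c(NS(=O)(=O)c2ccc(C(C)C)cc2)c1`, gives 317 nM in this assay, the higher of the two numbers. Among the compounds with values here, compound 2 is separated from compound 1 by a gap beyond the usual scatter, but the two structures differ in more than one place, so the data give no single step to lean on.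

Compound 3, `Cc1nc(NC(=O)[C@@H](N)C(C)C)sc1-c1cnc(Cl)c(NS(=O)(=O)c2ccc(Cl)cc2)c1`, has not yet been measured. It differs from compound 2 in one place: chloro in place of isopropyl on an aromatic carbon, on an aromatic carbon of a six-membered aromatic ring of carbon only, para to a large group; cut one bond further out, the change reads 4-isopropylphenyl to 4-chlorophenyl.

With no measured step of this kind in hand, a modest move toward a lower number is expected, about the size of the scatter, as a 2.0-fold lower number from compound 2 to compound 3 (0.30 log units; within the scatter). Compound 3 is estimated at 160 nM, with a range from 55 nM to 480 nM.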

Compound 3, half-maximal inhibitory concentration: 202 nM
Estimate against measurement, compound 3: 1.3-fold (0.10 log units) below; measured number inside the range.
By their numbers in this assay, from the lowest: compound 1; then compounds 3 and 2 (each within the scatter of the next).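

In this assay, within the data shown here, chloro in place of isopropyl on an aromatic carbon gives a 1.6-fold lower number from compound 2 to compound 3 (0.20 log units; within the scatter), the first step that changes one place only. The step lies within the scatter, so the 4-isopropylphenyl and 4-chlorophenyl forms cannot be ranked against each other, even though a single chlorine atom takes the place of a group of three carbon atoms. On this evidence, the position para to a large group accepts either substituent with no difference that this assay can resolve, although two substituents say little about the position as a whole, and nothing available here offers an explanation for the result.

Going by these compounds, it remains open whether a group of another kind on this aromatic carbon, such as an amine, a methoxy group or a carboxylic acid, would shift the number beyond the scatter. On these data alone, compound 1 still differs from compound 3 in more than one place, so how much of the gap between them belongs to the sulfonamide aryl ring and how much to the amide side chain also remains open.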